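The compounds below may be only part of what the source reports. "The series", "measured", "known", "first", "only" and "open" are said of these compounds alone.

Compound 1 `COC(=O)N[C@H](C(=O)NN(CCC[C@@](O)(Cc1ccccc1)C(=O)N[C@H]1c2ccccc2C[C@H]1O)Cc1ccc(C#N)cc1)C(C)(C)C`: > 10000 nM
Compound 2 `COC(=O)N[C@H](C(=O)NN(CCC[C@@](O)(Cc1ccccc1)C(=O)N[C@H]1c2ccccc2C[C@H]1O)CC(C)C)C(C)(C)C`: > 10000 nM
Compound 3 `COC(=O)N[C@H](C(=O)NN(CCC[C@@](O)(Cc1ccccc1)C(=O)N[C@H]1c2ccccc2C[C@H]1O)Cc1ccc(-c2nccs2)cc1)C(C)(C)C`: > 10000 nM

In an ADME assay on MT4 cells (Homo sapiens) for cytotoxicity (on this read-out higher numbers stand for lower toxicity in this test and lower numbers for higher toxicity in this test), compound 3 gives > 10000 nM, and this is a limit, not a number. Within the data shown here, the other two entries are limits as well, so the series so far shows only (the limit of > 10000 nM in this assay, at which 3 of the 3 values shown sit). No ranking of the three compounds can be read from this.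

Compound 4 `COC(=O)N[C@H](C(=O)NN(CCC[C@@](O)(Cc1ccccc1)C(=O)N[C@H]1c2ccccc2C[C@H]1O)Cc1ccc(I)cc1)C(C)(C)C` carries iodo in place of 1,3-thiazol-2-yl on an aromatic carbon, the group that compound 3 holds there: iodo in place of 1,3-thiazol-2-yl on an aromatic carbon.

The closest measured change, at the same aromatic carbon, is a step that the two limits leave unreadable from compound 1 to compound 3. Two changes further out give no size either: a step that the two limits leave unreadable from compound 1 to compound 2 and a step that the two limits leave unreadable from compound 2 to compound 3. Even so, none of these changes produced a measurable number.

Among the measured compounds shown here, for compound 4, no step of readable size is expected in this assay because of the limit of > 10000 nM in this assay, at which 3 of the 3 values shown sit. The expected step is a step that the limit leaves unreadable from compound 3 to compound 4. The estimate for compound 4 is 20000 nM, with an expected range from 8000 nM to 50000 nM.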

Compound 4, half-maximal cytotoxic concentration: > 10000 nM
Compound 4: a limit, no number; the forecaster's own chance of this, stated with the estimate: 85%; the middle value lies beyond the limit too.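

In this assay, among these compounds, compound 4 also gives only a limit, not a number, so no step between it and compound 1, compound 2 or compound 3 can be read: the limit of > 10000 nM in this assay, at which 4 of the 4 values shown sit. The compounds shown leave open whether exchanging these groups changes toxicity in this test at all.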